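This account rests on a few compounds, and the source may have more. Where it says the series, first, only, none or still open, it means among the compounds named here.

In a functional assay on MDA-MB-231 cells (Homo sapiens) for antiproliferative activity, read by sulforhodamine B assay, with a stated time of 48 h (on this read-out higher numbers stand for weaker inhibition of growth and lower numbers for stronger inhibition of growth), three compounds sharing one core have been measured: compound 1 `ClC1=C(c2nnc(-c3ccccc3)o2)CCCc2ccccc21` gives 1970 nM, compound 2 `Cc1ccc(-c2nnc(C3=C(Cl)c4ccccc4CCC3)o2)cc1` gives 1400 nM and compound 3 `O=[N+]([O-])c1ccc(-c2nnc(C3=C(Cl)c4ccccc4CCC3)o2)cc1` gives 3280 nM. Compound 2 cannot be separated from compound 1, as a 1.4-fold lower number from compound 1 to compound 2 (0.15 log units; within the scatter) shows, and only compound 3 stands apart from it: a 2.3-fold higher number from compound 2 to compound 3 (0.37 log units; beyond the scatter). Compound 4 `ClC1=C(c2nnc(-c3cccc(I)c3)o2)CCCc2ccccc21` changes the same group on the core: 3-iodophenyl in place of 4-methylphenyl on an aromatic carbon. The nearest evidence is these steps and a 1.7-fold higher number from compound 1 to compound 3 (0.22 log units; within the scatter), all small, though none of them tests iodine. A small step in this assay is therefore expected, with no firm direction. The expected step is a 1.3-fold higher number from compound 2 to compound 4 (0.11 log units; within the scatter). For compound 4 the estimated value is 1800 nM, with an expected range from 700 nM to 4500 nM.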

Compound 4, concentration for 50% growth inhibition: 4940 nM
Estimate against measurement, compound 4: 2.7-fold (0.44 log units) below; measured number above the stated range.
By their numbers in this assay, from the lowest: compounds 2, 1, 3 and 4 (each within the scatter of the next, the first and the last beyond it).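

Iodo gives the first change on the phenyl ring of compound 1 to reach beyond the scatter (a 2.5-fold higher number from compound 1 to compound 4 (0.40 log units; beyond the scatter)), and it moves toward weaker inhibition of growth. The other step (a 3.5-fold higher number from compound 2 to compound 4 (0.55 log units; beyond the scatter)) swaps the group and shifts its place on that ring together, so it cannot show which of the two matters. Nothing available explains why the number rises.

As far as these compounds go, it remains open whether iodo and methyl would differ if held at one place on the phenyl ring. From the compounds shown here alone, it is also open whether an amine there would raise the number too.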